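The source may report more compounds than this note shows. Statements on the series, on what has been measured and on what is new or still open speak of the compounds shown alone.

Measured so far in a functional assay on MCF7 cells (Homo sapiens) for cytotoxicity, read by MTT assay, with a stated time of 48 h; a lower number here means that less compound is needed, a higher number that more compound is needed for the effect:
compound 1 `Cc1c(O)c(=O)ccn1CC(=O)N/N=C1\C(=O)N(CC(=O)Nc2ccc(Cl)cc2)c2ccccc21`, 31400 nM
compound 2 `Cc1c(O)c(=O)ccn1CC(=O)N/N=C1\C(=O)N(CC(=O)Nc2ccccc2)c2ccccc21`, 48400 nM
compound 3 `CC(=O)Nc1ccc(NC(=O)CN2C(=O)/C(=N\NC(=O)Cn3ccc(=O)c(O)c3C)c3ccccc32)cc1`, 51900 nM

Compound 1 has the lowest of the three numbers, yet both of its steps stay within the scatter: a 1.5-fold higher number from compound 1 to compound 2 (0.19 log units; within the scatter) and a 1.7-fold higher number from compound 1 to compound 3 (0.22 log units; within the scatter), as does a 1.1-fold higher number from compound 2 to compound 3 (0.03 log units; within the scatter). Compound 4 `Cc1c(O)c(=O)ccn1CC(=O)N/N=C1\C(=O)N(CC(=O)Nc2ccccc2Cl)c2ccccc21` keeps the same atoms as compound 1 and differs only by 2-chlorophenyl in place of 4-chlorophenyl on an amide-type nitrogen. Going by the values given here, no measured step moves the chlorine around that ring; the three steps that exchange the substituent on it all remain within the scatter, so within these compounds this part of the molecule appears tolerant of change. For compound 4 the expected step is a 1.3-fold higher number from compound 1 to compound 4 (0.11 log units; within the scatter), none beyond the scatter. Compound 4 is therefore estimated at 40000 nM in this assay, with a range from 15000 nM to 100000 nM.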

Compound 4, half-maximal effective concentration: 46400 nM
Compound 4: middle estimate off by 1.2-fold (0.06 log units), on the low side; the range from low to high includes it.
By their numbers in this assay, from the lowest: compounds 1, 4, 2 and 3 (each within the scatter of the next).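

Moving the chlorine from 4-chlorophenyl to 2-chlorophenyl on the amide-type nitrogen gives the first reading of where it sits on this ring, and in this assay the change stays within the scatter, at a 1.5-fold higher number from compound 1 to compound 4 (0.17 log units; within the scatter). The 2-chlorophenyl group also stays within the scatter when set against the other two substituent patterns, at a 1.0-fold lower number from compound 2 to compound 4 (0.02 log units; within the scatter) and a 1.1-fold lower number from compound 3 to compound 4 (0.05 log units; within the scatter). No supporting measurement accounts for these small steps.

Still open, from the compounds shown here alone, is whether an amine or a carboxylic acid on this ring would give any step beyond the scatter.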